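A Bromine-for-Chlorine Swap and Expected Tolerance on Vero Cells

The source may report more compounds than this note shows. Statements on the series, on what has been measured and on what is new or still open speak of the compounds shown alone.

Two compounds on a shared core have been examined in an ADME assay on Vero cells (Chlorocebus sabaeus) for cytotoxicity, read by XTT assay, with a stated time of 72 h; a higher number here means that more compound is tolerated, a lower number that less compound is tolerated. Compound 1 `CC1=C(C(=O)Nc2ccc(Br)cc2)C(c2ccccc2)NC(=O)N1` reaches only a limit of the assay, giving > 100000 nM. Compound 2 `CC1=C(C(=O)Nc2ccccc2Cl)C(c2ccccc2Cl)NC(=O)N1` carries no single number in this assay, being reported as "non-toxic" (no number reported). Within the data shown here, the only other value shown, that of compound 1, is a limit, namely (the limit of > 100000 nM in this assay, at which 1 of the 2 values shown sits). Among the measured compounds shown here, no step between measured compounds is available, so nothing ties a structural change to a change in tolerance. Compound 3 `CC1=C(C(=O)Nc2ccccc2Cl)C(c2ccccc2Br)NC(=O)N1` differs from compound 2 by bromo in place of chloro on an aromatic carbon. With both measured compounds tolerated up to the top of the tested range, the expected step from compound 2 to compound 3 in this assay is none beyond the scatter, in either direction. Compound 3 is therefore estimated at 100000 nM, within a range of 30000 nM to 300000 nM, most likely again reported only as a limit.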

Compound 3, half-maximal cytotoxic concentration: > 100000 nM
Compound 3 gave a limit, no number; the forecaster's own chance of this, stated with the estimate: 75%; the middle value lies on the limit itself.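

In this assay compound 3 gives > 100000 nM, which is a limit. Among these compounds, compound 2 carries no number there, so no step between compound 2 and compound 3 can be read. The compounds shown leave open whether bromo in place of chloro changes tolerance at all, and how far tolerance extends for any of them.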